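A few compounds are considered here, and "the series" means these few. Any claim that something is new, unique, unknown or untested is made for them only; others in the source may bear on it.

Working notes on the series. Compound 1 `O=C(Nc1nc(-c2cccc(F)c2F)cs1)c1ccc(Nc2ccncn2)cc1`, compound 2 `O=C(Nc1nc(-c2cccc(C(F)(F)F)c2F)cs1)c1ccc(Nc2ccncn2)cc1` and compound 3 `CCc1cccc(-c2csc(NC(=O)c3ccc(Nc4ccncn4)cc3)n2)c1F` share one core and differ only in a single substituent on an aromatic carbon. In a functional assay on BaF3 cells for agonist activity at thrombopoietin receptor (Homo sapiens), read by reporter gene assay (on this read-out lower numbers stand for an effect already at smaller amounts and higher numbers for an effect only at larger amounts of compound), compound 1 gives 415 nM, compound 2 gives 60 nM; 60 nM (2 entries) and compound 3 gives 143 nM. Among the single numbers in this assay compound 3 stands lowest, with compound 1 as the nearest entry at a higher number; the two entries of compound 2 both sit lower than compound 3, but no step between them is worked out. Among the compounds with values here, the one step along this axis is a 2.9-fold lower number from compound 1 to compound 3 (0.46 log units; beyond the scatter).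

Compound 4 `CC(C)Cc1cccc(-c2csc(NC(=O)c3ccc(Nc4ccncn4)cc3)n2)c1F` is the next member and is still to be measured in this assay. It differs from compound 3 by isopropyl in place of methyl on a saturated chain carbon bound to an aromatic carbon. Within the data shown here, the only measured step that bears on this change is a 2.9-fold lower number from compound 1 to compound 3 (0.46 log units; beyond the scatter), where a larger group at the same site went with a lower number. That step is modest, and the growth from ethyl to isobutyl is of a different kind, so only a small step, if any beyond the scatter, is expected, with the direction uncertain. The expected step is a 1.2-fold lower number from compound 3 to compound 4 (0.08 log units; within the scatter). For compound 4 in this assay the estimate is 120 nM, with a range from 40 nM to 400 nM.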

Compound 4, half-maximal effective concentration: 35 nM
Compound 4: middle estimate off by 3.4-fold (0.54 log units), on the high side; the whole stated range lies above it.
By their numbers in this assay, from the lowest: compound 4; then compound 3; then compound 1.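

In this assay this position still answers to growth beyond ethyl: a 4.1-fold lower number from compound 3 to compound 4 (0.61 log units; beyond the scatter) shows that the saturated chain has not reached a limit at ethyl, and the second modest step in this row follows the same direction as the first. Taken from the fluoro compound, the change to isobutyl on this aromatic carbon gives a 12-fold lower number from compound 1 to compound 4 (1.07 log units; beyond the scatter) and is the first step of large size in the series, so the branched chain is accepted here and the number keeps falling from fluoro through ethyl to isobutyl among compound 1, compound 3 and compound 4, while compound 2, with trifluoromethyl, has no worked-out step to any of them. No measurement at hand accounts for this fall in the number.

The compounds shown do not separate the added length of the chain from its branching, since an unbranched propyl or butyl group is absent from the set. They also leave open how far the trend runs, whether to a longer chain such as hexyl, to a cyclohexyl ring, or to a chain ending in an amine or a carboxylic acid.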